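The source may hold more compounds than are shown below. What is called first, only, known or untested is meant among the compounds shown, and "the series" means these compounds.

Compound 1 `Cc1ccc(-c2cn(/N=C/c3cc4ccccc4nc3Cl)c(N)n2)cc1` in a functional assay on MDA-MB-231 cells (Homo sapiens) for cytotoxicity, read by MTT assay, with a stated time of 48 h (on this read-out higher numbers stand for weaker inhibition and lower numbers for stronger inhibition), gives > 50000 nM, which is a limit of the assay and not a number.
Compound 2 `COc1ccc(-c2cn(/N=C/c3cc4ccccc4nc3Cl)c(N)n2)cc1` in this assay gives > 50000 nM, again a limit and not a number.
Compound 3 `Cc1ccc(-c2cn(/N=C/c3cc4cc(C)ccc4nc3Cl)c(N)n2)cc1` in this assay gives 22300 nM.

Compound 3 therefore stands as the only one of the three with an actual number; the other two sit at the limit of > 50000 nM in this assay, at which 2 of the 3 values shown sit. Within the data shown here, the one readable step, an at least 2.2-fold lower number from compound 1 to compound 3 (0.35 log units; beyond the scatter), shows that adding a methyl on the bicyclic part of the shared core brought the number down out of the limit. The step that the two limits leave unreadable from compound 1 to compound 2 cannot be read at all, since both ends are limits.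

Compound 4 `Cc1ccc2nc(Cl)c(/C=N/n3cc(-c4ccc(Cl)cc4)nc3N)cc2c1` differs from compound 3 by chloro in place of methyl on an aromatic carbon. Among the measured compounds shown here, no measured step tests chloro against methyl at that place, and the only other change made there, from compound 1 to compound 2, gives no readable size. With nothing to point either way, the expectation for compound 4 in this assay is a step of a 1.1-fold lower number from compound 3 to compound 4 (0.05 log units; within the scatter), that is, no change beyond the scatter. Compound 4 is thus estimated at 20000 nM, with a range from 7000 nM to 50000 nM.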

Compound 4, half-maximal inhibitory concentration: 35200 nM
Beside the measured number, compound 4's estimate is 1.8-fold (0.25 log units) below it, within the range that was stated.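

Among these compounds, this is the first readable comparison at the position on the phenyl ring: in this assay, going from 4-methylphenyl to 4-chlorophenyl gives a 1.6-fold higher number from compound 3 to compound 4 (0.20 log units; within the scatter). Compound 3 and compound 4 therefore cannot be told apart here, so on this core, which carries the extra methyl on its bicyclic part, chloro and methyl at this place read as equivalent. The earlier change at the same place, methoxy for methyl, cannot be read, because both of its ends are limits and not numbers: the limit of > 50000 nM in this assay, at which 2 of the 4 values shown sit.

The pair says nothing about whether chloro would give a number on the core without the extra methyl, or what methoxy would give on the core with it, since only compounds that differ in one place can be compared and no such pairs are shown. Nor do the compounds shown tell what an amine, a carboxylic acid or a longer chain such as butyl would do at this place, so the reach of this result is limited to methyl and chloro on this one core.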